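Primary amide in place of the ester on the naphthyl core

The source may hold more compounds than are shown below. What is called first, only, known or untested is meant among the compounds shown, and "the series" means these compounds.

Three compounds have been measured in an assay on isolated protein for inhibition of steroid 17-alpha-hydroxylase/17,20 lyase (Homo sapiens); a lower number here means a stronger inhibitor, a higher number a weaker inhibitor:
compound 1 `CC(C)NC(=O)c1ccc2cc(C(O)(c3c[nH]cn3)C(C)C)ccc2c1` gives 75 nM
compound 2 `CC(=O)c1ccc2cc(C(O)(c3c[nH]cn3)C(C)C)ccc2c1` gives 28 nM
compound 3 `COC(=O)c1ccc2cc(C(O)(c3c[nH]cn3)C(C)C)ccc2c1` gives 24 nM

Compound 3 has the lowest number of the three in this assay, but compound 2 stands within the scatter of it, so the two cannot be ordered; only compound 1 is clearly set apart, as the step of a 3.1-fold lower number from compound 1 to compound 3 (0.49 log units; beyond the scatter) shows.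

Compound 4 `CC(C)C(O)(c1ccc2cc(C(N)=O)ccc2c1)c1c[nH]cn1` is not yet measured. It differs from compound 3 in one place: amino in place of methoxy on a carbonyl carbon.

Within the data shown here, two measured steps bear on this. The step of a 3.1-fold lower number from compound 1 to compound 3 (0.49 log units; beyond the scatter) replaces an isopropylamino group on the carbonyl carbon by methoxy and lowers the number clearly, while a 1.2-fold lower number from compound 2 to compound 3 (0.07 log units; within the scatter), methoxy in place of methyl, stays within the scatter. Compound 4 returns to a nitrogen on the carbonyl carbon, as in compound 1, but without the isopropyl group. The expectation is therefore a number somewhat higher than that of compound 3 and no higher than that of compound 1, so compound 4 is estimated at 45 nM, with a range from 20 nM to 110 nM, which would mean an expected step of a 1.9-fold higher number from compound 3 to compound 4 (0.27 log units; within the scatter).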

Compound 4, half-maximal inhibitory concentration: 30 nM
Estimate against measurement, compound 4: 1.5-fold (0.18 log units) above, and the stated range covers the measured number.
By their numbers in this assay, from the lowest: compounds 3, 2 and 4 (each within the scatter of the next); then compound 1.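

In this assay, amino in place of methoxy on the carbonyl carbon makes no difference that can be read (a 1.3-fold higher number from compound 3 to compound 4 (0.10 log units; within the scatter)), and the same holds for amino in place of methyl (a 1.1-fold higher number from compound 2 to compound 4 (0.03 log units; within the scatter)), so a nitrogen on this carbonyl carbon does not by itself separate a compound from those carrying methoxy or methyl there. Among these compounds, what sets compound 1 apart is the isopropyl group on that nitrogen: with hydrogen in its place, the number falls beyond the scatter (a 2.5-fold lower number from compound 1 to compound 4 (0.40 log units; beyond the scatter)), and this is the only clear step that the primary amide adds to the series. No measurement is available that would explain either result.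

The compounds shown leave open how the number responds to a methyl or an ethyl group on the amide nitrogen, and so whether the rise seen with isopropyl builds gradually or appears only with a group of that size. They also leave open whether a carboxylic acid or a nitrile in place of the carbamoyl group would stay within the scatter of compound 4.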